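Changing the benzyl group: from compound 2 to compound 3

The compounds below may be only part of what the source reports. "The series", "measured", "known", "first", "only" and "open" are said of these compounds alone.

Measured so far:
compound 1, `CC(C)(C)c1ccc(CNCCCNS(=O)(=O)c2cc(C(F)(F)F)cc(C(F)(F)F)c2)cc1`: 2000 nM
compound 2, `O=S(=O)(NCCCNCc1cccc(Cl)c1)c1cc(C(F)(F)F)cc(C(F)(F)F)c1`: 14000 nM

Within the data shown here, in a functional assay on HT-29 cells (Homo sapiens) for inhibition, read by MTT assay, with a stated time of 72 h (a lower number here means a stronger inhibitor of growth, a higher number a weaker inhibitor of growth), compound 2 gives 14000 nM, the highest of the two numbers so far; its nearest neighbour is compound 1, which in this assay gives 2000 nM. Among the measured compounds shown here, the only measured step that bears on the benzyl group is a 7.0-fold higher number from compound 1 to compound 2 (0.85 log units; beyond the scatter), a modest loss when the ring substituent was exchanged. Compound 3, `O=S(=O)(NCCCNCc1ccc(C(F)(F)F)cc1)c1cc(C(F)(F)F)cc(C(F)(F)F)c1`, differs from compound 2 by 4-(trifluoromethyl)phenyl in place of 3-chlorophenyl on a saturated chain carbon bound to an amine nitrogen. For the measured compounds named here, that step offers the single point of reference: exchanging the substituted phenyl at this position moved the number by a modest amount, beyond the scatter, and no second step shows how a trifluoromethyl on that ring behaves. A move back toward compound 1 is therefore expected, but a smaller one, and not with confidence beyond the scatter. Compound 3 is estimated at 5000 nM (range 1500 nM to 15000 nM). That estimate means an expected step of a 2.8-fold lower number from compound 2 to compound 3 (0.45 log units; beyond the scatter).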

Compound 3, concentration for 50% growth inhibition: 2900 nM
Beside the measured number, compound 3's estimate is 1.7-fold (0.24 log units) above it; the range from low to high includes it.
By their numbers in this assay, from the lowest: compounds 1 and 3 (each within the scatter of the next); then compound 2.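

In this assay, at this place on a saturated chain carbon bound to an amine nitrogen, 4-(trifluoromethyl)phenyl gives a 4.8-fold lower number from compound 2 to compound 3 (0.68 log units; beyond the scatter), so a second ring substituent now stands apart from 3-chlorophenyl, as 4-(tert-butyl)phenyl did with a 7.0-fold higher number from compound 1 to compound 2 (0.85 log units; beyond the scatter). Trifluoromethyl in place of tert-butyl on an aromatic carbon gives a 1.5-fold higher number from compound 1 to compound 3 (0.16 log units; within the scatter), so these two groups cannot be told apart here and tert-butyl is not needed for the lower number. No measurement to hand accounts for either step.

Compound 2 differs from the other two in both the substituent and its printed ring number, so these two changes cannot be separated. On these data alone, whether 4-chlorobenzyl, plain benzyl or a longer chain in place of the present one would keep the number remains open.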